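This account rests on a few compounds, and the source may have more. Where it says the series, first, only, none or still open, it means among the compounds named here.

Working notes on the series. Among the measured compounds shown here, compound 2 `O=C(Nc1ccccc1)Nc1ccc(OCc2nc3ccccc3s2)cc1` is the lower of the two numbers measured so far: in an assay on isolated protein for inhibition of Polyunsaturated fatty acid 5-lipoxygenase (Homo sapiens), read by HPLC, with a stated time of 10 min (on this read-out lower numbers stand for stronger inhibition and higher numbers for weaker inhibition), compound 2 gives 420 nM. For the measured compounds named here, compound 1 `Cc1cc(NC(=O)Nc2ccc(Cl)c(Cl)c2)ccc1OCc1nc2ccccc2s1`, which carries both a methyl group and a 3,4-dichlorophenyl group, gives 2170 nM in this assay; it differs from compound 2 in two places, so the pair shows only that its number lies beyond the scatter above that of compound 2. Compound 3 `O=C(Nc1ccc(OCc2nc3ccccc3s2)cc1)Nc1ccc(Cl)c(Cl)c1` is not yet measured. It differs from compound 2 in one place: 3,4-dichlorophenyl in place of phenyl on an amide-type nitrogen. Going by the values given here, no single-point step has been measured, so the expected size rests on the fact that compound 1, the only other compound bearing the 3,4-dichlorophenyl group, gives 2170 nM, a weaker number. The step of a 2.6-fold higher number from compound 2 to compound 3 (0.42 log units; beyond the scatter) is therefore expected to run towards weaker inhibition, of modest size, with a wide range. Compound 3 is estimated at 1100 nM, between 350 nM and 3500 nM.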

Compound 3, half-maximal inhibitory concentration: 570 nM
Beside the measured number, compound 3's estimate is 1.9-fold (0.29 log units) above it, within the range that was stated.
By their numbers in this assay, from the lowest: compounds 2 and 3 (each within the scatter of the next); then compound 1.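

In this assay, 3,4-dichlorophenyl in place of phenyl on an amide-type nitrogen gives a 1.4-fold higher number from compound 2 to compound 3 (0.13 log units; within the scatter) with no separation between the two numbers, so this position accepts the two chlorine atoms without a change that can be read. Hydrogen in place of methyl on an aromatic carbon gives a 3.8-fold lower number from compound 1 to compound 3 (0.58 log units; beyond the scatter) and is the step that goes beyond the scatter, which separates the two differences that the pair of compound 1 and compound 2 left joined. No data in hand give a reason for the size of either step.

From the compounds shown here alone, whether the methyl group brings a similar step when phenyl sits on the amide-type nitrogen remains open. Also open, going by these compounds, is how this position responds to a group of another kind, such as a carboxylic acid or an amine on the phenyl ring.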